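Cytotoxicity in a Series of Substituted Aminoquinoline Diamines

The source may hold more compounds than are shown below. What is called first, only, known or untested is meant among the compounds shown, and "the series" means these compounds.

Measured compounds in an ADME assay on HepG2 cells (Homo sapiens) for cytotoxicity, read by luminescence, CellTiter-Glo and ATP content, with a stated time of 72 h; a higher number here means that more compound is needed for the effect, a lower number that less compound is needed:
compound 1, `COc1ccc(F)cc1CNCCCNc1ccnc2cc(C3CCCCC3)ccc12`, gives 2290 nM
compound 2, `COc1ccc(F)cc1CNCCCNc1ccnc2cc(Oc3ccc(F)cc3)ccc12`, gives 6600 nM
compound 3, `COc1ccc(F)cc1CNCCCNc1ccnc2cc(-c3ccc(F)cc3)ccc12`, gives 770 nM

Compound 3 gives the lowest number of the three: the change from compound 1 is a 3.0-fold lower number from compound 1 to compound 3 (0.47 log units; beyond the scatter), and that from compound 2 is an 8.6-fold lower number from compound 2 to compound 3 (0.93 log units; beyond the scatter), while a 2.9-fold higher number from compound 1 to compound 2 (0.46 log units; beyond the scatter) separates the other two. Compound 4, `COc1ccc(-c2ccc3c(NCCCNCc4cc(F)ccc4OC)ccnc3c2)cc1`, differs from compound 3 in methoxy in place of fluoro on an aromatic carbon. Among the measured compounds shown here, no measured step changes a substituent at that place; all three vary the whole group attached to the shared core. The change is therefore expected to be small, and a step of a 1.2-fold higher number from compound 3 to compound 4 (0.09 log units; within the scatter) is estimated. Compound 4 is expected to give about 950 nM, within 380 nM to 2400 nM.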

Compound 4, half-maximal effective concentration: 5960 nM
Compound 4: middle estimate off by 6.3-fold (0.80 log units), on the low side, outside the stated range (above it).
By their numbers in this assay, from the lowest: compound 3; then compound 1; then compounds 4 and 2 (each within the scatter of the next).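

In this assay, exchanging only the fluoro for methoxy para to a large group moves the number substantially (a 7.7-fold higher number from compound 3 to compound 4 (0.89 log units; beyond the scatter)), so a small change at this place matters as well as the whole-group changes. With 4-methoxyphenyl, the result lies on the other side of the cyclohexyl compound (a 2.6-fold higher number from compound 1 to compound 4 (0.42 log units; beyond the scatter)) and cannot be told apart from the 4-fluorophenoxy compound (a 1.1-fold lower number from compound 2 to compound 4 (0.04 log units; within the scatter)), so a directly attached aromatic ring alone does not give the low number of compound 3. Nothing available explains this step. On these data alone, whether chloro or an amine at this place would resemble fluoro or methoxy remains open.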